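Fluoro in place of hydrogen on compound 2

The source may report more compounds than this note shows. Statements on the series, on what has been measured and on what is new or still open speak of the compounds shown alone.

Measured in a functional assay on HeLa cells (Homo sapiens) for inhibition; on this read-out higher numbers stand for weaker inhibition and lower numbers for stronger inhibition:
Compound 1 `Cc1cn(/C=C/C=O)c(=O)[nH]c1=O`: 100000 nM
Compound 2 `O=C/C=C/n1ccc(=O)[nH]c1=O`: 30000 nM
Compound 3 `Cc1cn(COCCO)c(=O)n(/C=C/C=O)c1=O`: 20000 nM

Compound 2 lies within the scatter of compound 3, while compound 1 gives a clearly higher number. Compound 4 `O=C/C=C/n1cc(F)c(=O)[nH]c1=O` carries fluoro in place of hydrogen on an aromatic carbon of compound 2: fluoro in place of hydrogen on an aromatic carbon. Among the compounds with values here, only one measured step bears on that carbon, the modest 3.3-fold lower number from compound 1 to compound 2 (0.52 log units; beyond the scatter). Within the data shown here, it swaps methyl for hydrogen, so it offers a guide to size, and no fluoro compound has been measured to fix the direction. A modest move to a lower number in this assay is nevertheless expected, and the expected step is a 2.5-fold lower number from compound 2 to compound 4 (0.40 log units; beyond the scatter). For compound 4 the estimated value is 12000 nM, with an expected range of 3000 nM to 40000 nM.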

Compound 4, half-maximal inhibitory concentration: 90000 nM
Beside the measured number, compound 4's estimate is 7.5-fold (0.88 log units) below it, outside the stated range (above it).
By their numbers in this assay, from the lowest: compounds 3 and 2 (each within the scatter of the next); then compounds 4 and 1 (each within the scatter of the next).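

In this assay, fluoro on this aromatic carbon gives a 3.0-fold higher number from compound 2 to compound 4 (0.48 log units; beyond the scatter) and so moves the same way as methyl, leaving hydrogen with the lowest number of the three groups shown at this carbon. Fluoro in place of methyl gives a 1.1-fold lower number from compound 1 to compound 4 (0.05 log units; within the scatter) and so does not separate these two groups. Nothing measured here gives a reason for this result. From the compounds shown here alone, whether chloro, trifluoromethyl or an amine on this carbon would also give a higher number than hydrogen stays open. So does whether hydrogen would keep its place on the core of compound 3.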